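Swapping the Amide-Linked Ring: From Compound 2 to Compound 3

The source may hold more compounds than are shown below. What is called first, only, known or untested is meant among the compounds shown, and "the series" means these compounds.

Measured so far in a functional assay on HEK293 cells for agonist activity at growth hormone secretagogue receptor type 1 (Homo sapiens), read by HTRF and inositol phosphate accumulation, with a stated time of 90 min, in the presence of a further agent that is not named here; on this read-out higher numbers stand for larger maximal responses and lower numbers for smaller maximal responses:
compound 1 `Cc1csc(C(=O)N[C@H]2CN(S(=O)(=O)c3ccccc3)C[C@@H]2C(=O)N[C@H]2CCCNC2)n1` gives 63%
compound 2 `O=C(N[C@H]1CN(S(=O)(=O)c2ccccc2)C[C@@H]1C(=O)N[C@H]1CCCNC1)c1cc(C2CC2)n[nH]1` gives 81%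

Compound 2 stands highest of the two numbers, its nearest neighbour being compound 1, which reached a number 18 percentage points higher from compound 1 to compound 2 (beyond the scatter). Compound 3 `O=C(N[C@H]1CN(S(=O)(=O)c2ccccc2)C[C@@H]1C(=O)N[C@H]1CCCNC1)c1nnc(-c2ccc(F)cc2)s1` differs from compound 2 only at the carbonyl carbon: a group of 12 heavy atoms (8 carbon, 2 nitrogen, 1 fluorine, 1 sulfur; one five-membered aromatic ring with 3 hetero atoms, one six-membered aromatic ring of carbon only) in place of a group of 8 heavy atoms (6 carbon, 2 nitrogen; one three-membered non-aromatic ring of carbon only, one five-membered aromatic ring with 2 hetero atoms), on a carbonyl carbon. For the measured compounds named here, the one step that bears on this place, a number 18 percentage points higher from compound 1 to compound 2 (beyond the scatter), shows that exchanging the group on this carbonyl carbon can shift the maximal response modestly. The entering group resembles neither of the two measured groups, and the direction is uncertain. A modest step downward is expected in this assay, a number 16 percentage points lower from compound 2 to compound 3 (beyond the scatter). Compound 3 is therefore estimated at 65%, within 40% to 90%.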

Compound 3, largest response reached (Emax), in percent of the reference or control that the assay uses: 89%
For compound 3 the middle estimate is 24 percentage points below the measured one; the range from low to high includes it.
By their numbers in this assay, from the lowest: compound 1; then compounds 2 and 3 (each within the scatter of the next).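

In this assay, the group on this carbonyl carbon can grow to 12 heavy atoms, carry a six-membered aromatic ring and lack a hydrogen-bond donor, and the maximal response still shows a number 8 percentage points higher from compound 2 to compound 3 (within the scatter). Against the 4-methyl-1,3-thiazol-2-yl group, the same entering group gives a number 26 percentage points higher from compound 1 to compound 3 (beyond the scatter), so compound 1 stands apart from the other two. Nothing at hand explains these results. Open, from the compounds shown here alone, is what an amine or a carboxylic acid in place of the fluorine would do to the response.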